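The source may report more compounds than this note shows. Statements on the series, on what has been measured and on what is new or still open speak of the compounds shown alone.

Compound 1 `CCOc1ccc(CN2CCC(C(=O)Nc3cc(Cl)c(N)cc3OC)CC2)cc1`: 6.3 mg/kg. Compound 2 `COc1cc(N)c(Cl)cc1NC(=O)C1CCN(Cc2ccccc2F)CC1`: only a limit.

In a functional assay on the whole organism for antagonist activity, with Mus musculus as the target (a lower number here means that less compound is needed, a higher number that more compound is needed for the effect), compound 1 gives 6.3 mg/kg. In this assay compound 2 gives only the limit > 4 mg/kg, not a number. Because of the limit of > 4 mg/kg in this assay, at which 1 of the 2 values shown sits, the step that the limit leaves unreadable from compound 1 to compound 2 cannot be read in size. Compound 3 `COc1cc(N)c(Cl)cc1NC(=O)C1CCN(Cc2ccsc2)CC1` differs from compound 2 by thiophen-3-yl in place of 2-fluorophenyl on a saturated chain carbon bound to an amine nitrogen in a ring. Going by the values given here, no measured step bears readably on this change, so no direction can be drawn from the numbers. The expected step is a step that the limit leaves unreadable from compound 2 to compound 3, with no direction beyond the scatter. Compound 3 is therefore estimated at 6 mg/kg, in the range 2 mg/kg to 20 mg/kg, with a fair chance that this assay again reports only a limit.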

Compound 3, dose for half-maximal effect: 3.4 mg/kg
For compound 3 the middle estimate is 1.8-fold (0.25 log units) above the measured one, and the stated range covers the measured number.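

Compound 3 shows that a five-membered aromatic ring, thiophen-3-yl, on this saturated chain carbon still gives a readable number in this assay. Against 4-ethoxyphenyl the change reads as a 1.9-fold lower number from compound 1 to compound 3 (0.27 log units; within the scatter), so these two groups cannot be told apart here. Against 2-fluorophenyl there is only an at least 1.1-fold lower number from compound 2 to compound 3 (0.07 log units; that floor lies within the scatter), and its true size stays unknown: the limit of > 4 mg/kg in this assay, at which 1 of the 3 values shown sits.

From the compounds shown here alone, whether a pyridine ring or a furan ring on the same carbon would move the number beyond the scatter stays open. So does the real value of compound 2.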